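The source may report more compounds than this note shows. Statements on the series, on what has been measured and on what is new or still open speak of the compounds shown alone.

Compound 3 `COc1nc(N)nc2c1c(-c1ccoc1)cn2[C@@H]1O[C@H](CO)[C@@H](O)[C@H]1O` is the weakest point so far in an ADME assay on MRC5 cells (Homo sapiens), read by MTT assay, with a stated time of 72 h; on this read-out higher numbers stand for weaker inhibition and lower numbers for stronger inhibition: in this assay compound 3 gives only a limit, > 100000 nM. Compound 1 `COc1nc(N)nc2c1c(-c1cc3ccccc3o1)cn2[C@@H]1O[C@H](CO)[C@@H](O)[C@H]1O` gives 22700 nM in this assay, and compound 2 `COc1ncnc2c1c(-c1ccco1)cn2[C@@H]1O[C@H](CO)[C@@H](O)[C@H]1O` gives 1700 nM. Going by the values given here, the one measured step, an at least 4.4-fold higher number from compound 1 to compound 3 (0.64 log units; beyond the scatter), moved toward the limit at the limit of > 100000 nM in this assay, at which 1 of the 3 values shown sits, so the single-ring furan-3-yl sits weaker than the fused 1-benzofuran-2-yl here.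

Compound 4 `COc1nc(N)nc2c1c(-c1ccco1)cn2[C@@H]1O[C@H](CO)[C@@H](O)[C@H]1O` is compound 3 with furan-2-yl in place of furan-3-yl on an aromatic carbon. Among the compounds with values here, no measured step covers this change directly. Compound 2 carries furan-2-yl on the same core without the amino group and gives a number well inside the range of the assay, and the 2-yl attachment of compound 1 also gives a number rather than a limit; on that footing a return from the limit is expected, with the estimated step of an at least 5.0-fold lower number from compound 3 to compound 4 (0.69 log units; beyond the scatter). The estimate for compound 4 in this assay is 20000 nM, in the range 5000 nM to 90000 nM.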

Compound 4, half-maximal inhibitory concentration: 89700 nM
Compound 4: middle estimate off by 4.5-fold (0.65 log units), on the low side; the measured number falls inside the stated range.
By their numbers in this assay, from the lowest: compound 2; then compound 1; then compound 4. At a limit, above all of these: compound 3.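

In this assay the change from furan-3-yl to furan-2-yl gives an at least 1.1-fold lower number from compound 3 to compound 4 (0.04 log units; that floor lies within the scatter) and so does not separate the two attachments, since the reading for compound 3 is a limit: the limit of > 100000 nM in this assay, at which 1 of the 4 values shown sits.
Amino in place of hydrogen on an aromatic carbon gives a 53-fold higher number from compound 2 to compound 4 (1.72 log units; beyond the scatter) and is the largest step shown, so with furan-2-yl in place the amino change counts for far more than the attachment change can yet be shown to.
Furan-2-yl in place of 1-benzofuran-2-yl gives a 4.0-fold higher number from compound 1 to compound 4 (0.60 log units; beyond the scatter) as a step between two measured numbers, where the matching step to furan-3-yl rested on a limit.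

Open, going by these compounds, is whether the amino step has the same size with 1-benzofuran-2-yl or furan-3-yl on the shared core.
Also open, on these data alone, is how a dimethylamino group or a chlorine would read in place of that amino group.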